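From Fluoro to Chloro on One Aromatic Carbon

This account rests on a few compounds, and the source may have more. Where it says the series, first, only, none or still open, it means among the compounds named here.

In a functional assay on MCF7 cells (Homo sapiens) for antiproliferative activity, read by MTT assay, with a stated time of 48 h (on this read-out lower numbers stand for stronger inhibition and higher numbers for weaker inhibition), compound 1 (`c1ccc(-c2nn(-c3ccccc3)cc2-c2nc3ccccc3[nH]2)cc1`) gives 3190 nM and compound 2 (`Fc1ccc(-c2nn(-c3ccccc3)cc2-c2nc3ccccc3[nH]2)cc1`) gives 3200 nM, so compound 2 stands level with compound 1 on these numbers. Compound 3 (`Clc1ccc(-c2nn(-c3ccccc3)cc2-c2nc3ccccc3[nH]2)cc1`) differs from compound 2 by a single exchange, chloro in place of fluoro on an aromatic carbon. Among the measured compounds shown here, only one measured step bears on this exchange, the one that put fluoro in place of hydrogen on an aromatic carbon, a 1.0-fold higher number from compound 1 to compound 2 (0.00 log units; within the scatter). For the measured compounds named here, that step stays within the scatter, and no measured compound yet carries chloro, so the evidence is thin. No shift beyond the scatter, in either direction, is therefore expected in this assay. The estimated change is a 1.1-fold lower number from compound 2 to compound 3 (0.03 log units; within the scatter), which is expected to remain within the scatter. For compound 3 the expected value is 3000 nM, with an estimated range of 1500 nM to 6000 nM.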

Compound 3, half-maximal inhibitory concentration: 3030 nM
Compound 3: middle estimate off by 1.0-fold (0.00 log units), on the low side, and the stated range covers the measured number.
By their numbers in this assay, from the lowest: compounds 3, 1 and 2 (each within the scatter of the next).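

In this assay the exchange of 4-fluorophenyl to 4-chlorophenyl reads as a step (a 1.1-fold lower number from compound 2 to compound 3 (0.02 log units; within the scatter)), and chloro in place of hydrogen reads the same way (a 1.1-fold lower number from compound 1 to compound 3 (0.02 log units; within the scatter)). The earlier compounds had shown only fluoro and hydrogen on this aromatic carbon, para to a large group; with chloro added, all three compounds now lie within the scatter of one another. Nothing available here accounts for this lack of separation.

The compounds shown leave open whether a group of another kind on this carbon, such as an amine, a carboxylic acid or a methoxy group, would move the number beyond the scatter. They also leave open whether chloro in place of hydrogen would read the same way elsewhere on the shared core.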